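The compounds below may be only part of what the source reports. "The series", "measured", "known", "first", "only" and "open" are said of these compounds alone.

Compound 1 `O=C(/C=C/c1ccccc1)N1CCc2c(Cl)c(O)c(O)c(Cl)c2C1`: 83%
Compound 2 `O=C(CCCc1ccc([N+](=O)[O-])cn1)N1CCc2c(Cl)c(O)c(O)c(Cl)c2C1`: 74%
Compound 3 `O=C(CCCc1ccc(C(F)(F)F)cn1)N1CCc2c(Cl)c(O)c(O)c(Cl)c2C1`: 72%

In a functional assay (Homo sapiens), tested at 1 uM (on this read-out lower numbers stand for a stronger effect and higher numbers for a weaker effect at the one concentration tested), compound 2 stands second highest of the three numbers. Its nearest neighbour is compound 3, with a step of a number 2 percentage points lower from compound 2 to compound 3 (within the scatter). Compound 1 gives 83%, which lies within the scatter of compound 2. The new compound 4 `CS(=O)(=O)c1ccc(CCCC(=O)N2CCc3c(Cl)c(O)c(O)c(Cl)c3C2)nc1` differs from compound 2 in one place: methylsulfonyl in place of nitro on an aromatic carbon. Going by the values given here, the only measured step that bears on this exchange is the one to compound 3, where a trifluoromethyl in place of nitro on an aromatic carbon gave a number 2 percentage points lower from compound 2 to compound 3 (within the scatter). A comparable outcome is therefore expected here, with no step beyond the scatter in this assay. The expected step is a number 1 percentage points lower from compound 2 to compound 4 (within the scatter). Compound 4 is estimated at 73%, within a range from 60% to 86%.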

Compound 4, a percentage reported as activity, at one concentration (the size of the read-out at that concentration, not a potency): 99%
Compound 4: middle estimate off by 26 percentage points, on the low side; the whole stated range lies below it.
By their numbers in this assay, from the lowest: compounds 3, 2 and 1 (each within the scatter of the next, the first and the last beyond it); then compound 4.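

Methylsulfonyl in place of nitro gives a number 25 percentage points higher from compound 2 to compound 4 (beyond the scatter) in this assay at this place on the ring, so an exchange of nitro here need not stay within the scatter, as the trifluoromethyl exchange had. Methylsulfonyl in place of trifluoromethyl gives a number 27 percentage points higher from compound 3 to compound 4 (beyond the scatter) at the same place, which shows that the read-out depends on which group sits para to the large group. Nothing available gives a reason for this difference. As far as these compounds go, whether an amine or a carboxylic acid at this place would read like methylsulfonyl or like nitro stays open.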